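A few compounds are considered here, and "the series" means these few. Any claim that something is new, unique, unknown or untested is made for them only; others in the source may bear on it.

Compound 1, `CC(C)C[C@H](N)CN(C(=O)[C@@H]1C[C@H]1c1ccccc1)c1ccc(-c2ccccc2)cc1`: 880 nM
Compound 2, `CC(C)C[C@H](N)CCN(C(=O)[C@@H]1C[C@H]1c1ccccc1)c1ccc(-c2ccccc2)cc1`: 3 nM
Compound 3, `CC[C@H](C)[C@H](N)CN(C(=O)[C@@H]1C[C@H]1c1cccc(F)c1)c1ccc(-c2ccccc2)cc1`: 560 nM

All three were tested in a functional assay for agonist activity at G protein-coupled receptor 88 (Homo sapiens), read by HTRF and cAMP accumulation; on this read-out higher numbers stand for an effect only at larger amounts of compound and lower numbers for an effect already at smaller amounts. Compound 3 stands second highest of the three numbers; its nearest neighbour is compound 1, which lies within the scatter of it, while compound 2 lies far lower, beyond the scatter. Within the data shown here, the only step between compounds differing in one place is a 290-fold lower number from compound 1 to compound 2 (2.47 log units; beyond the scatter), a change of 2-amino-4-methylpentyl in place of 1-amino-3-methylbutyl on a saturated chain carbon bound to an amide-type nitrogen; it does not touch the group on the three-membered non-aromatic ring of carbon only.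

Compound 4, `CC[C@H](C)[C@H](N)CN(C(=O)[C@@H]1C[C@H]1c1cccnc1)c1ccc(-c2ccccc2)cc1`, is compound 3 with pyridin-3-yl in place of 3-fluorophenyl on a saturated ring carbon. Among the measured compounds shown here, no measured step bears on this change, so the step of a 1.4-fold higher number from compound 3 to compound 4 (0.15 log units; within the scatter) is expected to be small. Compound 4 is estimated at 800 nM, with a range from 250 nM to 3000 nM.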

Compound 4, half-maximal effective concentration: 1500 nM
Compound 4: the middle estimate sits 1.9-fold (0.27 log units) below what was measured; the range from low to high includes it.
By their numbers in this assay, from the lowest: compound 2; then compounds 3, 1 and 4 (each within the scatter of the next, the first and the last beyond it).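

In this assay, among these compounds, the group on the saturated ring carbon of the three-membered ring turns out to matter: a 2.7-fold higher number from compound 3 to compound 4 (0.43 log units; beyond the scatter) is the only measured step at this position and lies beyond the scatter. It remains much smaller than the chain change, a 290-fold lower number from compound 1 to compound 2 (2.47 log units; beyond the scatter). Nothing on hand explains the step.

The compounds shown do not separate the loss of fluorine from the arrival of the ring nitrogen, and a 3-chlorophenyl or pyridin-2-yl group could help to do so. As far as these compounds go, whether pyridin-3-yl would have a similar effect on the 2-amino-4-methylpentyl chain of compound 2 also remains open.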